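The compounds below may be only part of what the source reports. "The series", "measured", "known", "first", "only" and "open" are said of these compounds alone.

In an ADME assay on microsomes from liver (Mus musculus) for metabolic stability, with a stated time of 10 min (a lower number here means that less of the compound is left, a higher number that more of the compound is left), compound 1 (`O=C(O)C1CCN(C(=O)N2CC[C@](c3ccc(C(F)(C(F)(F)F)C(F)(F)F)cc3)(S(=O)(=O)c3ccc(F)cc3)C2)CC1`) gives 88%, compound 2 (`O=C(O)[C@H]1CC[C@H](C(=O)N2CC[C@](c3ccc(C(F)(C(F)(F)F)C(F)(F)F)cc3)(S(=O)(=O)c3ccccc3)C2)CC1`) gives 96% and compound 3 (`Cc1ccc(S(=O)(=O)[C@@]2(c3ccc(C(F)(C(F)(F)F)C(F)(F)F)cc3)CCN(C(=O)[C@H]3CC[C@H](C(=O)O)CC3)C2)cc1`) gives 85%. Compound 2 thus stands within the scatter of compound 1 but clear of compound 3. Compound 4 (`Cc1cc(S(=O)(=O)[C@@]2(c3ccc(C(F)(C(F)(F)F)C(F)(F)F)cc3)CCN(C(=O)[C@H]3CC[C@H](C(=O)O)CC3)C2)ccc1F`) has not yet been measured. It departs from compound 2 as follows: 4-fluoro-3-methylphenyl in place of phenyl on a sulfonyl sulfur. Going by the values given here, one measured step bears directly on this change: methyl in place of hydrogen on an aromatic carbon gave a number 11 percentage points lower from compound 2 to compound 3 (beyond the scatter). Compound 4 carries a methyl too, so a modest fall of similar size is expected. Among the compounds with values here, compound 1 also holds a fluorine in the matching part of the structure, but it differs from compound 2 elsewhere as well, so no measured step isolates the fluorine. The expected change is a number 12 percentage points lower from compound 2 to compound 4 (beyond the scatter), which would be a modest fall. For compound 4 the estimated value is 84%, with an expected range from 71% to 95%.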

Compound 4, percent of the compound remaining: 84%
Compound 4: the middle estimate sits on the measured number at the digits printed; the measured number falls inside the stated range.
By their numbers in this assay, from the lowest: compounds 4, 3, 1 and 2 (each within the scatter of the next, the first and the last beyond it).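

In this assay the change on the sulfonyl sulfur gives a number 12 percentage points lower from compound 2 to compound 4 (beyond the scatter) and so adds a second substituted phenyl that stands beyond the scatter of the unsubstituted phenyl of compound 2. Set against the 4-methylphenyl of compound 3, the 4-fluoro-3-methylphenyl gives a number 1 percentage points lower from compound 3 to compound 4 (within the scatter) and so does not separate the two compounds in this read-out. Nothing at hand says why these substituted phenyl groups read as they do.

Going by these compounds alone, compound 1 is the only other compound with a fluorine in this part, and it differs from compound 2 elsewhere as well, so the step for fluorine alone stays open. Also open, as far as these compounds go, is how a phenyl carrying an amine or a nitrile on the sulfonyl sulfur would read in this assay against compound 2.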